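This account rests on a few compounds, and the source may have more. Where it says the series, first, only, none or still open, it means among the compounds named here.

Compound 1 `Cc1cc(C)c(Oc2cc(NCCn3ccc(=O)[nH]c3=O)nc(Cl)n2)c(C)c1` and compound 3 `Cc1cc(C)c(Oc2cc(Cl)nc(NCCn3ccc(=O)[nH]c3=O)n2)c(C)c1` are built from the same atoms joined differently; the difference between the two cores is not broken down here. In an ADME assay on MT4 cells (Homo sapiens) for cytotoxicity, read by MTT assay, with a stated time of 5 days (a lower number here means that less compound is tolerated, a higher number that more compound is tolerated), compound 1 gives 76400 nM, and compound 3 gives 44100 nM. These two numbers lie within the usual scatter of each other, so no order between them can be read. Compound 2 `Cc1cc(C)cc(Oc2cc(Cl)nc(NCCn3ccc(=O)[nH]c3=O)n2)c1` is made from compound 3 by 3,5-dimethylphenyl in place of 2,4,6-trimethylphenyl on an oxygen on an aromatic ring. For compound 2 this assay reports only a limit, > 56400 nM, which sits at the limit of > 56400 nM in this assay, at which 1 of the 3 values shown sits. The step is an at least 1.2-fold higher number from compound 3 to compound 2 (0.10 log units; that floor lies within the scatter). Compound 4 `Cc1cc(C)cc(Oc2cc(NCCn3ccc(=O)[nH]c3=O)nc(Cl)n2)c1` stands to compound 1 as compound 2 stands to compound 3: the change is 3,5-dimethylphenyl in place of 2,4,6-trimethylphenyl on an oxygen on an aromatic ring, the same change at the same place. Because an at least 1.2-fold higher number from compound 3 to compound 2 (0.10 log units; that floor lies within the scatter) gives only a floor that lies within the scatter, compound 4 is expected to give about the number of compound 1 or somewhat more. The estimate for compound 4 in this assay is 90000 nM, between 45000 nM and 180000 nM. The expected step is a 1.2-fold higher number from compound 1 to compound 4 (0.07 log units; within the scatter).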

Compound 4, half-maximal cytotoxic concentration: 99500 nM
For compound 4 the middle estimate is 1.1-fold (0.04 log units) below the measured one; low and high end bracket the measured number.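

In this assay, putting 3,5-dimethylphenyl in place of 2,4,6-trimethylphenyl gives a 1.3-fold higher number from compound 1 to compound 4 (0.11 log units; within the scatter). Set beside the same change on the other core, the result reads: the same change on two cores in this assay, an at least 1.2-fold higher number (0.10 log units; that floor lies within the scatter) from compound 3 to compound 2 and a 1.3-fold higher number (0.11 log units; within the scatter) from compound 1 to compound 4; the limit leaves it open whether they differ. Going by these compounds alone, the one full step lies within the scatter and the other is only a floor resting on a limit, so the pair does not show that this change raises the number, nor that it has the same size on both cores; it shows only that neither core gives a sign of a clear drop in the number.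

Within the data shown here, only two phenyl groups appear here, both carrying nothing but methyl groups, so it remains open what a phenyl ring bearing an amine or a carboxylic acid would give in this assay. These compounds also leave open whether the change would behave the same way on a core carrying a longer chain in place of the one shown.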